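From bromo to tert-butyl on the aromatic ring

The source may report more compounds than this note shows. Statements on the series, on what has been measured and on what is new or still open speak of the compounds shown alone.

Within the data shown here, in a functional assay on HCT-116 cells (Homo sapiens) for antiproliferative activity, read by MTT assay, with a stated time of 72 h (on this read-out higher numbers stand for weaker inhibition and lower numbers for stronger inhibition), compound 3 (`O=C(CCc1cccc2c1B(O)OC2)Nc1ccc(Br)cc1`) gives 46000 nM, the only true number so far. Compound 1 (`CCNC(=O)CCc1cccc2c1B(O)OC2`) gives > 100000 nM, which is a limit of the assay. Compound 2 (`O=C(CCc1cccc2c1B(O)OC2)NC1CCCCC1`) gives > 100000 nM, also a limit.

Compound 4 (`CC(C)(C)c1ccc(NC(=O)CCc2cccc3c2B(O)OC3)cc1`) has tert-butyl in place of bromo on an aromatic carbon, para to a large group (tert-butyl in place of bromo on an aromatic carbon). Among the measured compounds shown here, two measured steps bear on this only loosely: an at least 2.1-fold lower number from compound 1 to compound 3 (0.33 log units; beyond the scatter) and an at least 2.1-fold lower number from compound 2 to compound 3 (0.33 log units; beyond the scatter). Each replaced the whole group on the amide-type nitrogen, while this change keeps the aromatic ring. Only a small change is therefore expected, within the scatter: a 1.2-fold lower number from compound 3 to compound 4 (0.06 log units; within the scatter). Compound 4 is estimated at 40000 nM, with an expected range of 15000 nM to 100000 nM.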

Compound 4, half-maximal inhibitory concentration: 19000 nM
Compound 4: middle estimate off by 2.1-fold (0.32 log units), on the high side; the range from low to high includes it.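

Keeping the aromatic ring and changing only the group on it, para to a large group, gives a 2.4-fold lower number from compound 3 to compound 4 (0.38 log units; beyond the scatter) in this assay. Among these compounds, this is the first step here between two true numbers, so its size can be read, and it shows that activity responds to the group at this position. Steps from compound 1 and compound 2 give only a minimum size: the limit of > 100000 nM in this assay, at which 2 of the 4 values shown sit.

A single pair, bromo and tert-butyl, sets no trend. From the compounds shown here alone, how an amine or a carboxylic acid at this position would compare remains open.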